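Three flat cytotoxicity values before compound 4 is measured

A few compounds are considered here, and "the series" means these few. Any claim that something is new, unique, unknown or untested is made for them only; others in the source may bear on it.

Measured in an ADME assay on SJ-G2 cells (Homo sapiens) for cytotoxicity, read by MTT assay, with a stated time of 72 h; on this read-out lower numbers stand for stronger inhibition of growth and higher numbers for weaker inhibition of growth:
compound 1 `CCCCCCCCCCNC(=O)C1C(C(=O)O)[C@@H]2CC[C@H]1O2`, 10000 nM
compound 2 `O=C(O)C1C(C(=O)NCC2Cc3ccsc3CO2)[C@H]2CC[C@@H]1O2`, 10000 nM
compound 3 `O=C(O)C1C(C(=O)Nc2ccc(CO)cc2)[C@H]2CC[C@@H]1O2`, 10000 nM

Compound 1 stands level with compounds 2 and 3 at the digits shown. Its nearest neighbour is compound 2, with no change at those digits, and its furthest is compound 3, again with no change, both within the scatter. Compound 4 `O=C(O)CCCNC(=O)C1C(C(=O)O)[C@@H]2CC[C@H]1O2` is the next member of the series and differs from compound 1 by carboxy in place of heptyl on a saturated chain carbon, three bonds along the chain from an amide-type nitrogen. Among the measured compounds shown here, no step between two measured compounds that differ in one place is available, so no guide to the size of this change exists, and the expected step from compound 1 to compound 4 is none beyond the scatter: no change at the digits printed from compound 1 to compound 4 (within the scatter). Compound 4 is therefore expected to give 10000 nM, within 6000 nM to 20000 nM, in this assay.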

Compound 4, concentration for 50% growth inhibition: 10000 nM
For compound 4 middle estimate and measured number coincide at the digits printed; measured number inside the range.
By their numbers in this assay, from the lowest: compounds 1, 2, 3 and 4 (each within the scatter of the next).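

In this assay, carboxy in place of heptyl on a saturated chain carbon, three bonds along the chain from an amide-type nitrogen, gives no change at the digits printed from compound 1 to compound 4 (within the scatter). Among the compounds shown here, this is the first step between compounds that differ in one place, and at this position the exchange leaves the read-out unmoved. Nothing measured here offers an explanation for this.

As far as these compounds go, whether an amine or a phenyl ring in this position would move the number remains open. So does whether any change on this chain can shift it.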